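Compound 1 to compound 4: replacing the silicon group

The source may hold more compounds than are shown below. What is called first, only, known or untested is meant among the compounds shown, and "the series" means these compounds.

In a functional assay on U-373MG ATCC cells for inhibition, with U373 MG (Homo sapiens) as the target, read by MTT assay, with a stated time of 7 days (on this read-out higher numbers stand for weaker inhibition of growth and lower numbers for stronger inhibition of growth), compound 1 `C[Si](C)(C)Cn1nnc2c(C(N)=O)ncn2c1=O` gives 45600 nM. Compound 2 `C[Si](C)(C)CCOCn1nnc2c(C(N)=O)ncn2c1=O` gives 25300 nM, and these two numbers lie within the scatter of each other. Compound 3 `COc1cc(Cn2nnc3c(C(N)=O)ncn3c2=O)cc(OC)c1OC` gives > 50000 nM. Going by the values given here, that value is a limit of the assay and not a number, so only two numbers are available for comparison, and compound 1 sits level with compound 2.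

Compound 4 `NC(=O)c1ncn2c(=O)n(Cc3c[nH]nn3)nnc12` has not yet been measured. Its difference from compound 1 is a group of 5 heavy atoms (2 carbon, 3 nitrogen; one five-membered aromatic ring with 3 hetero atoms) in place of a group of 4 heavy atoms (3 carbon, 1 silicon; no ring), on a saturated chain carbon bound to an aromatic nitrogen. Among the compounds with values here, the new group is 1H-1,2,3-triazol-4-yl, and it stands on a saturated chain carbon bound to an aromatic nitrogen, the same place that changes in the one measured step.

That step is a 1.8-fold lower number from compound 1 to compound 2 (0.26 log units; within the scatter). Within the data shown here, it is the only measured step that bears on this change, and no measured compound carries the 1H-1,2,3-triazol-4-yl group, so the evidence is thin. Given the size of that step for compound 2, no change beyond the scatter is expected in this assay, and the estimated step is a 1.1-fold higher number from compound 1 to compound 4 (0.02 log units; within the scatter). A limit rather than a number is also a likely outcome. For compound 4 the estimated value is 48000 nM, with an expected range of 22000 nM to 100000 nM.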

Compound 4, concentration for 50% growth inhibition: > 50000 nM
Compound 4: no number, only a limit; the forecaster's own chance of this, stated with the estimate: 50%; at least 1.0-fold (0.01 log units) between middle value and limit.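

Compound 4 gives > 50000 nM in this assay, a limit and not a number. With the 1H-1,2,3-triazol-4-yl group on this saturated chain carbon bound to an aromatic nitrogen, the readings are an at least 1.0-fold higher number from compound 1 to compound 4 (0.04 log units; that floor lies within the scatter) and an at least 1.9-fold higher number from compound 2 to compound 4 (0.29 log units; that floor lies within the scatter), so neither floor shows a step beyond the scatter, though the swap of a silicon group for this ring gives no sign of stronger inhibition of growth. Until now the limit rested on the ring group of compound 3 alone, and a second, quite different aromatic ring now sits there with it, while the two silicon groups of compound 1 and compound 2 are the only ones that give numbers: the limit of > 50000 nM in this assay, at which 2 of the 4 values shown sit.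

Going by these compounds, how far compound 3 and compound 4 lie past the limit remains unknown, and any steps involving the two of them together cannot be read. Also open, on these data alone, is whether silicon itself matters at this place, which a neopentyl group, with carbon in place of silicon, would address, and whether a ring-bearing group with an amine or a carboxylic acid would also stay at the limit.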